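A few compounds are considered here, and "the series" means these few. Any claim that something is new, unique, unknown or untested is made for them only; others in the source may bear on it.

Notes on the series in a functional assay on HeLa cells (Homo sapiens) for antiproliferative activity, read by MTT assay (a higher number here means a weaker inhibitor, a lower number a stronger inhibitor), start from compound 1 (`Cc1cccc(Nc2nccc(-c3ccc(Br)cc3)n2)c1`). Compound 1 gives 71000 nM and stands highest of the three measured numbers, beyond the scatter from both others. Compound 2 (`COc1cccc(Nc2nccc(-c3ccc(Cl)c(Cl)c3)n2)c1`) gives 4970 nM and compound 3 (`O=[N+]([O-])c1ccc(Nc2nccc(-c3ccc(F)cc3)n2)cc1`) gives 3510 nM and these two values lie within the scatter of each other.

Compound 4 (`Clc1ccc(Nc2nccc(-c3ccc(Br)cc3)n2)cc1`) is still unmeasured. It differs from compound 1 by 4-chlorophenyl in place of 3-methylphenyl on a nitrogen on an aromatic ring.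

Going by the values given here, no measured pair differs in one place, so no direct step is available. In this assay a move to a lower number, beyond the scatter, is expected. That expectation is loose: compound 2 at 4970 nM and compound 3 at 3510 nM also lack the 3-methylphenyl, but both differ from compound 1 elsewhere too. The estimated step (a 5.9-fold lower number from compound 1 to compound 4 (0.77 log units; beyond the scatter)) is therefore kept smaller than those gaps. The estimated value for compound 4 is 12000 nM with an expected range from 3500 nM to 45000 nM for now.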

Compound 4, half-maximal inhibitory concentration: 36700 nM
The estimate for compound 4 lay 3.1-fold (0.49 log units) below the measured number; the measured number falls inside the stated range.
By their numbers in this assay, from the lowest: compounds 3 and 2 (each within the scatter of the next); then compounds 4 and 1 (each within the scatter of the next).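

In this assay, going by these compounds alone, the first comparison that differs in one place is a 1.9-fold lower number from compound 1 to compound 4 (0.29 log units; within the scatter), with 4-chlorophenyl in place of 3-methylphenyl on a nitrogen on an aromatic ring. With the rest of the structure held fixed, this exchange of one substituted phenyl for another gives no move beyond the scatter, so this single change alone does not separate the two compounds. No measurement is at hand that would explain the result.

Going by these compounds, whether this position keeps the same number with a different kind of group, such as an amine or a carboxylic acid on the phenyl ring, stays open. Compound 2 and compound 3 each differ from compound 1 and compound 4 in more than one place, so the effect of any single change on their numbers cannot be read.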